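Methoxy in place of nitro on compound 2

The source may hold more compounds than are shown below. What is called first, only, known or untested is meant among the compounds shown, and "the series" means these compounds.

Measured so far in a physicochemical assay, with a stated time of 6 min; on this read-out lower numbers stand for stronger inhibition and higher numbers for weaker inhibition:
Compound 1 `O=C(Nc1ccc([N+](=O)[O-])cc1)Nc1nc(-c2cc3cc(Br)ccc3o2)cs1` gives > 200000 nM as a limit of the assay
Compound 2 `O=C(Nc1cccc([N+](=O)[O-])c1)Nc1nc(-c2cc3cc(Br)ccc3o2)cs1` gives 159000 nM
Compound 3 `O=C(Nc1ccc(I)cc1)Nc1nc(-c2cc3cc([N+](=O)[O-])ccc3o2)cs1` gives 62400 nM

Compound 2 holds the higher of the two actual numbers, and compound 3 is the lower one. Compound 4 `COc1cccc(NC(=O)Nc2nc(-c3cc4cc(Br)ccc4o3)cs2)c1`, not yet measured, carries methoxy in place of nitro on an aromatic carbon, meta to a large group (methoxy in place of nitro on an aromatic carbon). Among the compounds with values here, the one measured step with a bearing on this is an at least 1.2-fold lower number from compound 1 to compound 2 (0.09 log units; that floor lies within the scatter). It moves the nitro group and does not replace it. Within the data shown here, with only that step to rest on, no step beyond the scatter is expected in this assay. The expected step is a 1.1-fold lower number from compound 2 to compound 4 (0.06 log units; within the scatter). Compound 4 is estimated at 140000 nM, with an expected range from 45000 nM to 200000 nM.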

Compound 4, half-maximal inhibitory concentration: > 200000 nM
Compound 4: no number, only a limit; the forecaster's own chance of this, stated with the estimate: 30%; middle value at least 1.4-fold (0.15 log units) away from the limit.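

In this assay the replacement of nitro by methoxy on this aromatic carbon gives an at least 1.2-fold higher number from compound 2 to compound 4 (0.09 log units; that floor lies within the scatter) and so tests the group itself, where compound 1 and compound 2 differ only in where the nitro group sits. Compound 4 gives > 200000 nM as a limit of the assay and not a number. The step from compound 1 to compound 4 cannot be read, and the true size of the change stays out of sight at that limit: the limit of > 200000 nM in this assay, at which 2 of the 4 values shown sit.

On these data alone, what an amine or a carboxylic acid in place of nitro on this carbon would give stays open.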